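Moving the Chlorine on the Hydrazone Aryl Ring

The source may hold more compounds than are shown below. What is called first, only, known or untested is meant among the compounds shown, and "the series" means these compounds.

Measured so far in an assay on isolated protein for inhibition of Amine oxidase [flavin-containing] A (Homo sapiens), read by spectrophotometry; a lower number here means a stronger inhibitor, a higher number a weaker inhibitor:
compound 1 `COc1ccc(/C=N/Nc2nc3ccccc3nc2Cc2ccccc2)cc1OC` gives 56 nM
compound 2 `C(=N/Nc1nc2ccccc2nc1Cc1ccccc1)\c1ccccc1` gives 81 nM
compound 3 `Clc1ccc(/C=N/Nc2nc3ccccc3nc2Cc2ccccc2)cc1` gives 76 nM

The three compounds share one core and differ only in the aryl group on the carbon with a double bond to nitrogen. Compound 3 stands second highest of the three numbers; its nearest neighbour is compound 2 and its furthest is compound 1, and both gaps are within the scatter. The steps of a 1.4-fold higher number from compound 1 to compound 2 (0.16 log units; within the scatter), a 1.4-fold higher number from compound 1 to compound 3 (0.13 log units; within the scatter) and a 1.1-fold lower number from compound 2 to compound 3 (0.03 log units; within the scatter) all stay within the scatter, so exchanging one aryl group for another at this place has so far left this assay essentially unchanged.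

Compound 4 `Clc1ccccc1/C=N/Nc1nc2ccccc2nc1Cc1ccccc1` differs from compound 3 by 2-chlorophenyl in place of 4-chlorophenyl on a carbon with a double bond to nitrogen. Within the data shown here, no measured step moves a chlorine from one position of this ring to another; the steps that bear on it are the three aryl exchanges above, every one within the scatter. Compound 4 is therefore expected to show no step beyond the scatter, a 1.1-fold higher number from compound 3 to compound 4 (0.02 log units; within the scatter). Compound 4 is estimated at 80 nM, with a range from 40 nM to 170 nM.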

Compound 4, half-maximal inhibitory concentration: 5.8 nM
For compound 4 the middle estimate is 14-fold (1.14 log units) above the measured one; measured number below the stated range.
By their numbers in this assay, from the lowest: compound 4; then compounds 1, 3 and 2 (each within the scatter of the next).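

In this assay this position proved far more sensitive than the earlier aryl exchanges suggested: with the same atoms in both groups, 2-chlorophenyl in place of 4-chlorophenyl gives a 13-fold lower number from compound 3 to compound 4 (1.12 log units; beyond the scatter) and thus separates two compounds that differ only in how the chlorine is attached. Chloro in place of hydrogen gives a 14-fold lower number from compound 2 to compound 4 (1.15 log units; beyond the scatter) here, whereas the printed step a 1.1-fold lower number from compound 2 to compound 3 (0.03 log units; within the scatter) shows no such change for the 4-chlorophenyl group, so the effect belongs to this arrangement and not to the presence of chlorine alone; 2-chlorophenyl in place of 3,4-dimethoxyphenyl likewise gives a 9.7-fold lower number from compound 1 to compound 4 (0.98 log units; beyond the scatter) and stands clear of the scatter. Nothing available accounts for this difference.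

On these data alone, it remains open whether the drop depends on chlorine itself, which bromo, fluoro or methoxy in place of the chloro of the 2-chlorophenyl group would test. As far as these compounds go, it is also open whether the drop would persist with an amine or a carboxylic acid added to the shared core.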